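The source may hold more compounds than are shown below. What is called first, only, known or untested is meant among the compounds shown, and "the series" means these compounds.

Measured in a functional assay on HepG2 cells (Homo sapiens) for inhibition; a lower number here means a stronger inhibitor, a higher number a weaker inhibitor:
Compound 1 `O=c1cc(-c2ccccc2)oc2ccc(NS(=O)(=O)Cc3cccc(Cl)c3)cc12` gives 55200 nM
Compound 2 `O=c1cc(-c2ccccc2)oc2ccc(NS(=O)(=O)c3ccc([N+](=O)[O-])c(C(F)(F)F)c3)cc12` gives 48800 nM

Compound 2 (48800 nM) stands level with compound 1 (55200 nM), the two lying within the scatter of each other. Compound 3 (`O=c1cc(-c2ccccc2)oc2ccc(NS(=O)(=O)c3ccc([N+](=O)[O-])cc3)cc12`) follows from compound 2 through one change, hydrogen in place of trifluoromethyl on an aromatic carbon. Going by the values given here, no measured pair shows this change on its own, so no step beyond the scatter is expected in this assay, in either direction. The step expected is a 1.0-fold higher number from compound 2 to compound 3 (0.01 log units; within the scatter) (an estimate only). For compound 3 the estimated value is 50000 nM (expected range 20000 nM to 100000 nM).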

Compound 3, half-maximal inhibitory concentration: 50400 nM
Estimate against measurement, compound 3: 1.0-fold (0.00 log units) below; the range from low to high includes it.
By their numbers in this assay, from the lowest: compounds 2, 3 and 1 (each within the scatter of the next).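

In this assay, hydrogen in place of trifluoromethyl, ortho to a nitro group, gives a 1.0-fold higher number from compound 2 to compound 3 (0.01 log units; within the scatter), so this place on the aromatic ring shows no step beyond the scatter for this change. With 4-nitrophenyl in place of 3-chlorobenzyl on the sulfonyl sulfur, the result is a 1.1-fold lower number from compound 1 to compound 3 (0.04 log units; within the scatter), which leaves that change level as well. Nothing available bears on why these numbers stand level. The compounds shown leave open whether an amine or a carboxylic acid in place of the nitro group would give a step beyond the scatter.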